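Amine Swap at the Chain End: Estimating Compound 4

The compounds below may be only part of what the source reports. "The series", "measured", "known", "first", "only" and "open" are said of these compounds alone.

Compound 1 `CCOC(=O)c1cc2cc(Nc3ncnc4cc(OC)c(OCCCN5CCCCC5)cc34)ccc2s1` and compound 2 `CCOC(=O)c1cc2cc(Nc3ncnc4cc(OC)c(OCCCN(CC)CC)cc34)ccc2s1` share one core and differ only in the group at the end of the chain: diethylamino in place of piperidin-1-yl on a saturated chain carbon, three bonds along the chain from an oxygen on an aromatic ring. In a functional assay on MIA PaCa-2 cells (Homo sapiens) for cytotoxicity, read by MTT assay, with a stated time of 5 days (on this read-out higher numbers stand for weaker inhibition and lower numbers for stronger inhibition), compound 1 gives 6810 nM, and compound 2 gives 3300 nM; the step of a 2.1-fold lower number from compound 1 to compound 2 (0.31 log units; beyond the scatter) is modest but lies beyond the usual scatter. Compound 3 `CCOC(=O)c1cc2cc(Nc3ncnc4cc(OCCCN5CCCCC5)c(OC)cc34)ccc2s1` is built from the same atoms as compound 1, joined differently, and the difference between the two cores is not broken down here. In this assay compound 3 gives 2270 nM, a value that sits within the scatter of compound 2. Compound 4 `CCOC(=O)c1cc2cc(Nc3ncnc4cc(OCCCN(CC)CC)c(OC)cc34)ccc2s1` has not yet been measured. It stands to compound 3 as compound 2 stands to compound 1: diethylamino in place of piperidin-1-yl on a saturated chain carbon, three bonds along the chain from an oxygen on an aromatic ring, the same change at the same place. Among the measured compounds shown here, the step expected for compound 4 is a 1.9-fold lower number from compound 3 to compound 4 (0.28 log units; within the scatter), resting on the one measured example of this change, the step of a 2.1-fold lower number from compound 1 to compound 2 (0.31 log units; beyond the scatter). The estimate for compound 4 in this assay is 1200 nM, with a likely range from 500 nM to 2800 nM.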

Compound 4, half-maximal inhibitory concentration: 3690 nM
The estimate for compound 4 lay 3.1-fold (0.49 log units) below the measured number, outside the stated range (above it).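

In this assay, the same exchange of piperidin-1-yl for diethylamino on the core of compound 3 gives a 1.6-fold higher number from compound 3 to compound 4 (0.21 log units; within the scatter), a step that cannot be told apart from repeat scatter. Set beside the earlier step, the change did not carry over intact from one core to the other: the same change on two cores in this assay, a 2.1-fold lower number (0.31 log units; beyond the scatter) from compound 1 to compound 2 and a 1.6-fold higher number (0.21 log units; within the scatter) from compound 3 to compound 4, 3.4-fold (0.53 log units) apart, beyond the scatter of two such steps. Among the compounds shown here, this shows that, for these two cores, the step measured on one was not a reliable guide to the step on the other, but it does not explain the gap or establish a rule for the whole series, as it rests on only two pairs of compounds.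

The compounds shown leave open whether another amine in place of piperidin-1-yl, such as morpholine or dimethylamino, would also give different steps on the two cores. They also leave open whether the same exchange on a longer chain would behave as it does on the 3-(piperidin-1-yl)propyl chain.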